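The compounds below may be only part of what the source reports. "The series", "measured", "known", "first", "only" and "open" are said of these compounds alone.

Compound 1 `COc1ccc(-c2cc3ccccc3nc2/C=C/C(=O)c2ccc(O)cc2)cc1` is a chalcone-like compound whose aryl ketone carries a 4-hydroxyphenyl group. In a functional assay on NCI-H1299 cells (Homo sapiens) for antiproliferative activity, read by XTT assay, with a stated time of 72 h (a higher number here means a weaker inhibitor, a lower number a stronger inhibitor), compound 1 gives 8970 nM. For the measured compounds named here, its only measured companion is compound 2 `COc1ccc(-c2cc3ccccc3nc2/C=C/C(=O)c2c(OC)cccc2OC)cc1`, which in this assay gives 4710 nM. Going by the values given here, the single known step, a 1.9-fold lower number from compound 1 to compound 2 (0.28 log units; within the scatter), replaces the 4-hydroxyphenyl with a 2,6-dimethoxyphenyl on the carbonyl carbon; the two values lie within the scatter of each other, so compound 1 cannot be set apart from compound 2 on these numbers.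

Compound 3 `COc1ccc(-c2cc3ccccc3nc2/C=C/C(=O)c2ccc(OC)c(OC)c2)cc1` differs from compound 1 in one place: 3,4-dimethoxyphenyl in place of 4-hydroxyphenyl on a carbonyl carbon. The step from compound 1 to compound 2 bears on this change, since there too the 4-hydroxyphenyl gave way to a dimethoxyphenyl on the same carbonyl carbon, and that step stayed within the scatter. The expected outcome for compound 3 is therefore a step of at most modest size toward a lower number in this assay, or none beyond the scatter, which is the meaning of the estimated 1.6-fold lower number from compound 1 to compound 3 (0.21 log units; within the scatter). Compound 3 is thus estimated at 5500 nM, with a range from 2500 nM to 12000 nM.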

Compound 3, half-maximal inhibitory concentration: 1050 nM
Beside the measured number, compound 3's estimate is 5.2-fold (0.72 log units) above it; the whole stated range lies above it.
By their numbers in this assay, from the lowest: compound 3; then compounds 2 and 1 (each within the scatter of the next).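

In this assay, for the compounds shown here, putting 3,4-dimethoxyphenyl in place of 4-hydroxyphenyl on a carbonyl carbon gives an 8.5-fold lower number from compound 1 to compound 3 (0.93 log units; beyond the scatter) and so shows that this place can shift the number beyond the scatter, which the only earlier step, lying within the scatter, could not show. The result also separates the two dimethoxyphenyl groups from each other: 3,4-dimethoxyphenyl in place of 2,6-dimethoxyphenyl gives a 4.5-fold lower number from compound 2 to compound 3 (0.65 log units; beyond the scatter) and so shows that carrying two methoxy groups is not enough for the lower number, since compound 2 carries them as well and stays within the scatter of compound 1. No measurement is available that explains why these groups differ in this way.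

The compounds shown leave open which of the two methoxy groups of compound 3 goes with the lower number, and whether a phenyl with a single methoxy group would keep it. They also leave open how an amine, a carboxylic acid or a longer ether chain on this ring would read in this assay and whether the step seen here would hold on a changed core.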